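A few compounds are considered here, and "the series" means these few. Any claim that something is new, unique, unknown or untested is made for them only; others in the source may bear on it.

Measured so far:
- compound 1 `COc1cc(C(=O)c2sc(-c3cccc([N+](=O)[O-])c3)cc2N)cc(OC)c1OC` gives 7.5 nM
- compound 2 `COc1cc(C(=O)c2sc(-c3ccsc3)cc2N)cc(OC)c1OC` gives 8.8 nM

Both values come from a functional assay on MOLT-4 cells (Homo sapiens) for antiproliferative activity; on this read-out lower numbers stand for stronger inhibition and higher numbers for weaker inhibition. Compound 2, at 8.8 nM, lies within the scatter of compound 1, so the two numbers cannot be separated.

Compound 3 `COc1cc(C(=O)c2sc(-c3ccc(F)cc3)cc2N)cc(OC)c1OC` is not yet measured. It carries 4-fluorophenyl in place of thiophen-3-yl on an aromatic carbon, next to the ring sulfur: 4-fluorophenyl in place of thiophen-3-yl on an aromatic carbon.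

For the measured compounds named here, only one measured step bears on this change. It falls at the same ring carbon and exchanges 3-nitrophenyl for thiophen-3-yl: a 1.2-fold higher number from compound 1 to compound 2 (0.07 log units; within the scatter). Going by the values given here, that step stays within the scatter, yet a single step is a thin basis, and no measured compound carries 4-fluorophenyl. The expectation in this assay is therefore for no shift beyond the scatter, with a wide range left open.

A step of a 1.4-fold higher number from compound 2 to compound 3 (0.13 log units; within the scatter) is expected, and its direction is not firmly set by the data. For compound 3 the estimated value is 12 nM, with an expected range from 4 nM to 40 nM.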

Compound 3, half-maximal inhibitory concentration: 12 nM
Compound 3: middle estimate and measured number agree at the digits printed; measured number inside the range.
By their numbers in this assay, from the lowest: compounds 1, 2 and 3 (each within the scatter of the next).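

In this assay the aromatic carbon next to the ring sulfur now carries three different aromatic rings, and both new steps stay within the scatter: a 1.4-fold higher number from compound 2 to compound 3 (0.13 log units; within the scatter) for 4-fluorophenyl in place of thiophen-3-yl, and a 1.6-fold higher number from compound 1 to compound 3 (0.20 log units; within the scatter) for 4-fluorophenyl in place of 3-nitrophenyl. For the compounds shown here, the earlier pair showed only that one five-membered ring and one substituted phenyl could not be separated; a second substituted phenyl, with a fluorine instead of a nitro group and at a different ring place, now cannot be separated from either of them. The series therefore shows no dependence on the choice among these three rings at this carbon, and no data accompany these numbers that would bear on why the values stay so close.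

On these data alone, all three groups are aromatic rings, so it stays open whether a group of another kind at this carbon, such as a morpholine, a carboxylic acid or a longer alkyl chain, would leave the number within the scatter. As far as these compounds go, the amino group on the shared core is the same throughout, so its part in the values also stays open.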